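The source may hold more compounds than are shown below. What is called first, only, known or untested is meant among the compounds shown, and "the series" means these compounds.

Measured so far:
compound 1 `COc1cc(-c2cc(/C=C/C(=O)c3ccc(N)cc3)[nH]n2)cc(OC)c1OC` gives -89%
compound 2 `COc1ccc(-c2cc(/C=C/C(=O)c3ccc(OC)c(OC)c3)[nH]n2)cc1` gives -98%
compound 3 `COc1cc(-c2cc(/C=C/C(=O)c3ccc(Cl)c(Cl)c3)[nH]n2)cc(OC)c1OC` gives 5%

In a functional assay on NCI-H322M cells (Homo sapiens) for cytotoxicity, read by sulforhodamine B assay, with a stated time of 48 h, tested at 100 uM (on this read-out higher numbers stand for a weaker effect at the one concentration tested and lower numbers for a stronger effect), compound 1 stands second highest of the three numbers; compound 2 lies within the scatter of it, while compound 3 lies far above it. For the measured compounds named here, the one measured step that starts from compound 1 is a number 94 percentage points higher from compound 1 to compound 3 (beyond the scatter), and it changes the ring on the carbonyl carbon, not the ring that is altered here.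

Compound 4 `COc1ccc(-c2cc(/C=C/C(=O)c3ccc(N)cc3)[nH]n2)cc1OC` differs from compound 1 in one place: hydrogen in place of methoxy on an aromatic carbon. Going by the values given here, no measured step removes a methoxy group from this ring, so nothing bears on the change directly. Among the compounds with values here, the only indirect hint is compound 2, which carries fewer methoxy groups on that ring than compound 1 does; in this assay compound 2 still gives -98%, and that number lies within the scatter of the number of compound 1. The expectation is therefore a step of a number 4 percentage points higher from compound 1 to compound 4 (within the scatter), that is, none beyond the scatter. Compound 4 is estimated at -85%, within a range of -100% to -40%.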

Compound 4, a percentage reported as activity, at one concentration (the size of the read-out at that concentration, not a potency): -88%
The estimate for compound 4 lay 3 percentage points above the measured number; the range from low to high includes it.
By their numbers in this assay, from the lowest: compounds 2, 1 and 4 (each within the scatter of the next); then compound 3.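

For the compounds shown here, putting hydrogen in place of methoxy on an aromatic carbon gives a number 1 percentage points higher from compound 1 to compound 4 (within the scatter), the first direct reading of this position. With the 4-aminophenyl group on the carbonyl carbon, this methoxy group is therefore not required for the strong effect seen at the one concentration tested in this assay, whereas changing the ring on the carbonyl carbon gives a number 94 percentage points higher from compound 1 to compound 3 (beyond the scatter). Nothing available explains why this change leaves the read-out within the scatter.

As far as these compounds go, it remains open whether a hydroxy group, an ethoxy group or a fluorine atom at this place would also leave the number within the scatter. From the compounds shown here alone, it is also open whether losing this methoxy group would matter as little in compound 3, which carries 3,4-dichlorophenyl on the carbonyl carbon and gives 5%.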